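The source may hold more compounds than are shown below. What is called first, only, known or untested is meant among the compounds shown, and "the series" means these compounds.

Working notes on the series. Of the compounds shown here, three on the shared core have been measured in a functional assay on UO-31 cells (Homo sapiens) for inhibition; a lower number here means a stronger inhibitor of growth, a higher number a weaker inhibitor of growth. Compound 1 `COc1cc(/C=C/C(=O)c2cccc(-n3cc(-c4ccc(Cl)cc4)[nH]c3=O)c2)cc(OC)c1OC` gives 7030 nM. Within the data shown here, compound 2 `COc1cc(/C=C/C(=O)c2cccc(-n3cc(-c4ccccc4)[nH]c3=O)c2)cc(OC)c1OC` gives 1510 nM; the only one-place step measured so far is a 4.7-fold lower number from compound 1 to compound 2 (0.67 log units; beyond the scatter). Compound 3 `COc1ccc(-c2cn(-c3cccc(C(=O)/C=C/c4ccc(O)c(OC)c4)c3)c(=O)[nH]2)cc1` gives 5190 nM, the second highest of the three numbers: the value of compound 3 lies within the scatter of the value of compound 1 and beyond the scatter of the value of compound 2, which is the lowest of the three.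

The next compound, compound 4 `COc1ccc(-c2cn(-c3cccc(C(=O)/C=C/c4cc(OC)c(OC)c(OC)c4)c3)c(=O)[nH]2)cc1`, is compound 3 with 3,4,5-trimethoxyphenyl in place of 4-hydroxy-3-methoxyphenyl on a double-bonded chain carbon bound to a double-bonded chain carbon. No measured step bears on this change: the single step shown, from compound 1 to compound 2, concerns hydrogen in place of chloro on an aromatic carbon and says nothing about the group on the double-bonded chain carbon. What is known is that compound 1 gives 7030 nM in this assay and already carries the same 3,4,5-trimethoxyphenyl that enters compound 4, a number within the scatter of compound 3. The expected step is therefore a 1.2-fold higher number from compound 3 to compound 4 (0.06 log units; within the scatter), not beyond the scatter. The estimate for compound 4 in this assay is 6000 nM, with a range from 2500 nM to 15000 nM.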

Compound 4, concentration for 50% growth inhibition: 1910 nM
The estimate for compound 4 lay 3.1-fold (0.50 log units) above the measured number; the measured number lies below the stated range.
By their numbers in this assay, from the lowest: compounds 2 and 4 (each within the scatter of the next); then compounds 3 and 1 (each within the scatter of the next).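

The group on a double-bonded chain carbon bound to a double-bonded chain carbon now has a measured step in this assay: 3,4,5-trimethoxyphenyl in place of 4-hydroxy-3-methoxyphenyl gives a 2.7-fold lower number from compound 3 to compound 4 (0.43 log units; beyond the scatter) and so this position does register in the read-out. With 3,4,5-trimethoxyphenyl held constant, the aromatic carbon gains a third group: methoxy in place of chloro gives a 3.7-fold lower number from compound 1 to compound 4 (0.57 log units; beyond the scatter) while methoxy in place of hydrogen gives a 1.3-fold higher number from compound 2 to compound 4 (0.10 log units; within the scatter) and that second step stays within the scatter. Across compound 1, compound 2 and compound 4, chloro is therefore the group that stands apart on that carbon, while methoxy and hydrogen cannot be told apart.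

From the compounds shown here alone, whether the step at the chain carbon keeps its size with hydrogen or chloro on the aromatic carbon remains open, as does the outcome with an amine or a carboxylic acid at either place. Nothing available gives a cause for any of these steps.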